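This account rests on a few compounds, and the source may have more. Where it says the series, first, only, none or still open, it means among the compounds named here.

Within the data shown here, compound 2 `CCOC(=O)c1cccc(-c2ccc(CN3CCCCC3)cc2)c1` gives 75000 nM in an assay on COS-7 cells for inhibition of patatin-like phospholipase domain-containing protein 2 (Mus musculus); on this read-out lower numbers stand for stronger inhibition and higher numbers for weaker inhibition; compound 1 `CCOC(=O)c1cccc(-c2ccc(OCC)cc2)c1` gives 50000 nM there, and the two lie within the scatter of each other, the only numbers so far. Compound 3 `CCOC(=O)c1cccc(-c2ccc(CN(C)C)cc2)c1` differs from compound 2 by dimethylamino in place of piperidin-1-yl on a saturated chain carbon bound to an aromatic carbon. Among the measured compounds shown here, the only measured step, a 1.5-fold higher number from compound 1 to compound 2 (0.18 log units; within the scatter), concerns a different exchange at that carbon and is itself small; nothing measured bears directly on shortening the amine. A step of no change at the digits printed from compound 2 to compound 3 (within the scatter) is therefore expected, that is, nothing beyond the scatter. For compound 3 the expected value in this assay is 75000 nM, in the range 30000 nM to 180000 nM.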

Compound 3, half-maximal inhibitory concentration: 150000 nM
Estimate against measurement, compound 3: 2.0-fold (0.30 log units) below; the range from low to high includes it.
By their numbers in this assay, from the lowest: compounds 1, 2 and 3 (each within the scatter of the next, the first and the last beyond it).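

The exchange of piperidin-1-yl for dimethylamino gives a 2.0-fold higher number from compound 2 to compound 3 (0.30 log units; within the scatter), so dropping the ring from the amine leaves the two compounds unseparated in this series. Against the ethoxy compound, (dimethylamino)methyl gives a 3.0-fold higher number from compound 1 to compound 3 (0.48 log units; beyond the scatter), the first step here beyond the scatter, though a modest one. No evidence bears on the cause of either step.

Open, from the compounds shown here alone, is how morpholin-4-yl or a primary amine would read on this saturated chain carbon. Also open, going by these compounds, is whether a carboxylic acid in place of the ethyl ester would shift these numbers.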